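The compounds below may be only part of what the source reports. "The series", "measured", "known", "first", "only" and "open" are said of these compounds alone.

Measured so far in a functional assay on the whole organism for antagonist activity, with Mus musculus as the target; on this read-out higher numbers stand for an effect only at larger amounts of compound and lower numbers for an effect already at smaller amounts:
- compound 1 `CCC(=O)N(c1ccc(Cl)cc1)C1CCCC1N(C)C`: 0.2 mg/kg
- compound 2 `CCC(=O)N(c1ccc(Cl)c(C)c1)C1CCCC1N(C)C`: 2 mg/kg

Among the compounds with values here, compound 1 holds the lower of the two numbers, and compound 2 is its only neighbour. Compound 3 `CCC(=O)N(c1ccc(C(F)(F)F)cc1)C1CCCC1N(C)C` has not yet been measured and keeps the core of compound 1, with one change: trifluoromethyl in place of chloro on an aromatic carbon. This is trifluoromethyl in place of chloro on an aromatic carbon.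

Within the data shown here, only one measured step bears on it, and only indirectly: a 10-fold higher number from compound 1 to compound 2 (1.00 log units; beyond the scatter), with methyl in place of hydrogen on an aromatic carbon. Among the measured compounds shown here, no measured compound carries trifluoromethyl, so the size of the new step remains uncertain. On that single step, a higher number is expected in this assay, though a smaller rise than the methyl step, and a result within the scatter remains possible. The estimate means an expected 2.5-fold higher number from compound 1 to compound 3 (0.40 log units; beyond the scatter). For compound 3 the expected value is 0.5 mg/kg, within an estimated range of 0.1 mg/kg to 3 mg/kg.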

Compound 3, dose for half-maximal effect: 25 mg/kg
For compound 3 the middle estimate is 50-fold (1.70 log units) below the measured one; the measured number lies above the stated range.
By their numbers in this assay, from the lowest: compound 1; then compound 2; then compound 3.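

Notes on the series: in this assay, the aromatic carbon para to a large group does not tolerate exchange of chloro for trifluoromethyl as a neutral swap: a 130-fold higher number from compound 1 to compound 3 (2.10 log units; beyond the scatter). Within the data shown here, the earlier step, a 10-fold higher number from compound 1 to compound 2 (1.00 log units; beyond the scatter), left chloro in place and added methyl on a different aromatic carbon, so this is the first read on the group at this carbon itself. The read-out proves highly sensitive to that group, and the exchange of one heavy atom for four heavy atoms gives the larger of the two steps. Nothing available bears on what lies behind this step.

Open, from the compounds shown here alone, is how bromo, methyl or methoxy on this carbon would read. Also open, going by these compounds, is whether hydrogen there would stand nearer compound 1 or compound 3.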